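This account rests on a few compounds, and the source may have more. Where it says the series, first, only, none or still open, it means among the compounds named here.

Series of acetamidoethyl thioethers measured in an assay on NIH3T3 cells for displacement of a labelled ligand from melatonin receptor type 1B (Homo sapiens), with a stated time of 90 min; a higher number here means a weaker inhibitor, a lower number a stronger inhibitor. For the measured compounds named here, compound 1 `CC(=O)NCCSc1ccccc1` gives 339 nM and stands lowest of the two numbers so far. Going by the values given here, compound 2 `COc1ccc(SCCNC(C)=O)cc1` carries a methoxy on an aromatic carbon and gives 2400 nM; the step of a 7.1-fold higher number from compound 1 to compound 2 (0.85 log units; beyond the scatter) is the only measured change in the set.

Compound 3 `COc1ccccc1SCCNC(C)=O` is not yet measured. It differs from compound 1 by methoxy in place of hydrogen on an aromatic carbon. Among the compounds with values here, the one measured step that bears on this change is a 7.1-fold higher number from compound 1 to compound 2 (0.85 log units; beyond the scatter), the same group entering at a different aromatic carbon, so it is a guide to direction rather than a direct precedent. The number for compound 3 is expected to rise because a 7.1-fold higher number from compound 1 to compound 2 (0.85 log units; beyond the scatter) went that way, though with no second methoxy placement measured the size is uncertain and a smaller move than the measured one is assumed; the expected step is a 2.9-fold higher number from compound 1 to compound 3 (0.47 log units; beyond the scatter). Compound 3 is therefore estimated at 1000 nM, with a range from 300 nM to 4000 nM. A result within the scatter of compound 1 would not be surprising.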

Compound 3, inhibition constant: 501 nM
Beside the measured number, compound 3's estimate is 2.0-fold (0.30 log units) above it, and the stated range covers the measured number.
By their numbers in this assay, from the lowest: compounds 1 and 3 (each within the scatter of the next); then compound 2.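

In this assay the methoxy entering on an aromatic carbon ortho to a group of 7 heavy atoms gives a 1.5-fold higher number from compound 1 to compound 3 (0.17 log units; within the scatter) and so leaves compound 3 indistinguishable from compound 1 in this assay. The earlier step (a 7.1-fold higher number from compound 1 to compound 2 (0.85 log units; beyond the scatter)) showed only that the same replacement, made at a different aromatic carbon, comes with a number beyond the scatter, so across these three compounds the outcome of this hydrogen-to-methoxy change depends on the aromatic carbon that carries it, and the set shows that a methoxy on this carbon is tolerated within the scatter of the unsubstituted compound 1. Nothing at hand gives a reason for the difference between the two methoxy placements.

The compounds shown leave open whether this aromatic carbon accepts other groups in the same way, such as a hydroxy, a chlorine, an ethoxy or a trifluoromethyl. They also leave open whether the tolerance of the methoxy in compound 3 would hold with a longer chain between the sulfur and the acetamide nitrogen.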